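From bromo to azido in a small series

The source may hold more compounds than are shown below. What is called first, only, known or untested is meant among the compounds shown, and "the series" means these compounds.

Measured so far in a functional assay on HCT-116 cells (Homo sapiens) for inhibition, read by CCK-8 assay, with a stated time of 48 h; a higher number here means a weaker inhibitor, a lower number a stronger inhibitor
compound 1 `COc1cc(N(Cc2ccc(Br)cc2)C(=O)CSC(=S)N2CCN(C(=O)OC(C)(C)C)CC2)cc(OC)c1OC` at 11400 nM
compound 2 `COc1ccc(CN(C(=O)CSC(=S)N2CCN(C(=O)OC(C)(C)C)CC2)c2cc(OC)c(OC)c(OC)c2)cc1F` at 8210 nM
compound 3 `COc1ccc(CN(C(=O)CSC(=S)N2CCN(C(=O)OC(C)(C)C)CC2)c2cc(OC)c(OC)c(OC)c2)cc1Br` at 9710 nM

Compound 3 does not separate from the other two compounds, as a 1.2-fold lower number from compound 1 to compound 3 (0.07 log units; within the scatter) and a 1.2-fold higher number from compound 2 to compound 3 (0.07 log units; within the scatter) both stay within the scatter. Compound 4 `COc1ccc(CN(C(=O)CSC(=S)N2CCN(C(=O)OC(C)(C)C)CC2)c2cc(OC)c(OC)c(OC)c2)cc1N=[N+]=[N-]` has not yet been measured. It differs from compound 3 in one place (azido in place of bromo on an aromatic carbon), with azido in place of bromo on an aromatic carbon, ortho to a methoxy group.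

Among the compounds with values here, no measured step involves an azido group, so the data offer no direct reading of this change. The closest evidence is bromo in place of fluoro on an aromatic carbon, seen in a 1.2-fold higher number from compound 2 to compound 3 (0.07 log units; within the scatter) as a step that stays small. The wider replacement of the aryl group in a 1.4-fold lower number from compound 1 to compound 2 (0.14 log units; within the scatter) also stays within the scatter. On this thin basis, no step beyond the scatter is expected in this assay in either direction, although three compounds are a narrow guide to a new group. The estimate for compound 4 means a 1.2-fold lower number from compound 3 to compound 4 (0.08 log units; within the scatter) as the expected step. Compound 4 is estimated at 8000 nM with an expected range from 3000 nM to 18000 nM in this read-out.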

Compound 4, half-maximal inhibitory concentration: 780 nM
Compound 4: middle estimate off by 10-fold (1.01 log units), on the high side; measured number below the stated range.
By their numbers in this assay, from the lowest: compound 4; then compounds 2, 3 and 1 (each within the scatter of the next).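

On the aromatic carbon ortho to a methoxy group, exchanging one halogen for another had given only a 1.2-fold higher number from compound 2 to compound 3 (0.07 log units; within the scatter) in this assay, which left open whether this position responds to its substituent at all, but azido gives a 12-fold lower number from compound 3 to compound 4 (1.10 log units; beyond the scatter) and an 11-fold lower number from compound 2 to compound 4 (1.02 log units; beyond the scatter). Replacing the whole aryl group now also moves the number beyond the scatter, with a 15-fold lower number from compound 1 to compound 4 (1.16 log units; beyond the scatter), whereas a 1.4-fold lower number from compound 1 to compound 2 (0.14 log units; within the scatter) and a 1.2-fold lower number from compound 1 to compound 3 (0.07 log units; within the scatter) stayed within it, so the methoxy-bearing ring alone does not set compound 4 apart, since compound 2 and compound 3 carry it too. The data offer no explanation for why azido differs so sharply from fluoro and bromo at this position.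

From the compounds shown here alone, it remains open whether this step is particular to azido or would also appear with another group at the same carbon, such as an amine, a nitrile or an ethynyl group. The compounds shown also leave open whether azido would give a similar step at another carbon of this ring, or in the absence of the neighbouring methoxy group.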